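Swapping Dichlorophenyl for Methoxyphenyl on a Shared Core

A few compounds are considered here, and "the series" means these few. Any claim that something is new, unique, unknown or untested is made for them only; others in the source may bear on it.

Of the compounds shown here, three built on one shared core have been tested in a functional assay on A498 cells (Homo sapiens) for inhibition, read by sulforhodamine B assay, with a stated time of 48 h; a lower number here means that less compound is tolerated, a higher number that more compound is tolerated. Compound 2 `Nc1cc(N)c2nc(-c3ccccc3)c(NCc3ccc(Cl)c(Cl)c3)nc2c1` gives 60300 nM, the higher of the two numbers available, though its gap to compound 3 `CCOC(=O)[C@H](CCC(=O)O)NC(=O)c1ccc(Oc2nc3cc(N)cc(N)c3nc2-c2ccccc2)cc1` at 33900 nM lies within the scatter. For compound 1 `CCOC(=O)[C@H](CCC(=O)O)NC(=O)c1ccc(CNc2nc3cc(N)cc(N)c3nc2-c2ccccc2)cc1` only a limit of < 100000 nM is known (the limit of < 100000 nM in this assay, at which 1 of the 3 values shown sits). Compound 4 `COc1ccc(CNc2nc3cc(N)cc(N)c3nc2-c2ccccc2)cc1` has not yet been measured in this assay; it differs from compound 2 by 4-methoxyphenyl in place of 3,4-dichlorophenyl on a saturated chain carbon bound to a nitrogen on an aromatic ring. For the measured compounds named here, no comparable step has been measured among the three, so the expected step of a 1.1-fold higher number from compound 2 to compound 4 (0.03 log units; within the scatter) is taken as nothing beyond the scatter. Compound 4 is therefore estimated at 65000 nM, with a range from 25000 nM to 180000 nM, and a fair chance that only a limit is reported.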

Compound 4, concentration lethal to 50% of the cells: < 100000 nM
Compound 4: a limit, no number (the forecaster's own chance of this, stated with the estimate: 35%); the middle value is on the limit's open side.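

For the compounds shown here, compound 4 gives only a limit of < 100000 nM and not a number, so no step from compound 2 to compound 4 can be read: the limit of < 100000 nM in this assay, at which 2 of the 4 values shown sit. The compounds shown leave open how 4-methoxyphenyl and 3,4-dichlorophenyl compare on the shared core.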